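Swapping Ethoxy for Formyl on a Shared Core

The source may report more compounds than this note shows. Statements on the series, on what has been measured and on what is new or still open speak of the compounds shown alone.

Compound 1, `CCCOc1cc(=O)oc2cc(OCc3cccc(F)c3)ccc12`: 407 nM
Compound 2, `CCOc1cc(=O)oc2cc(OCc3cccc(Cl)c3)ccc12`: 115 nM

Both compounds were tested in an assay on isolated protein (strain Sprague-Dawley) for inhibition of Amine oxidase [flavin-containing] B (Rattus norvegicus), read by spectrophotometry, with a stated time of 5 min; on this read-out lower numbers stand for stronger inhibition and higher numbers for weaker inhibition. Compound 2 gives the lower of the two numbers, and the gap to compound 1 lies beyond the scatter, so compound 2 is the stronger inhibitor of the pair. The two structures differ in more than one place at once, so the gap cannot be assigned to any single change. Compound 3, `O=Cc1cc(=O)oc2cc(OCc3cccc(Cl)c3)ccc12`, has not yet been measured. It keeps the chlorine-bearing side chain of compound 2 and differs from it in one place only: formyl in place of ethoxy on an aromatic carbon. Within the data shown here, no measured pair shows what this exchange does, so its size is uncertain. The expectation in this assay is a moderate step toward weaker inhibition, a 3.5-fold higher number from compound 2 to compound 3 (0.54 log units; beyond the scatter), though a step within the scatter cannot be ruled out. Compound 3 is therefore estimated at 400 nM, with a likely range from 80 nM to 2000 nM.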

Compound 3, half-maximal inhibitory concentration: 52.5 nM
Compound 3: middle estimate off by 7.6-fold (0.88 log units), on the high side, and the stated range ends above it.
By their numbers in this assay, from the lowest: compound 3; then compound 2; then compound 1.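

In this assay, putting formyl in place of ethoxy on this aromatic carbon, opposite the ring oxygen, gives a 2.2-fold lower number from compound 2 to compound 3 (0.34 log units; beyond the scatter), so the exchange moves toward stronger inhibition. Among these compounds, this is the first comparison here that changes one place only, with the chlorine-bearing side chain held fixed, and it shows that ethoxy is not needed at this position for inhibition at this level. No measurement shown here explains the step.

From the compounds shown here alone, compound 1 differs from both other compounds in more than one place, so its steps cannot be read, and whether formyl would bring the same gain alongside its fluorine-bearing side chain stays open. Also open, going by these compounds, is how other groups at this position, such as an amine, a carboxylic acid or a longer chain, would compare with formyl.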